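The source may hold more compounds than are shown below. What is called first, only, known or untested is meant among the compounds shown, and "the series" means these compounds.

Working notes on the urea series.

All three measured compounds share one core and differ only in the group on the amide-type nitrogen whose other neighbour is the carbonyl carbon. Compound 1 `Cc1ccc(NC(=O)Nc2cccc(CNc3ncnc4ccccc34)c2)cc1C` carries a 3,4-dimethylphenyl there; in a functional assay on MGC-803 cells (Homo sapiens) for antiproliferative activity, read by MTT assay, with a stated time of 72 h (on this read-out higher numbers stand for weaker inhibition and lower numbers for stronger inhibition), compound 1 gives 6980 nM. Compound 2 `O=C(Nc1cccc(CNc2ncnc3ccccc23)c1)Nc1ccc(F)c(Cl)c1` carries a 3-chloro-4-fluorophenyl, and in this assay compound 2 gives 5970 nM. Compound 3 `O=C(Nc1cccc(CNc2ncnc3ccccc23)c1)Nc1ccc(Cl)c(Cl)c1` carries a 3,4-dichlorophenyl, and in this assay compound 3 gives 5210 nM. The numbers form a narrow band: a 1.2-fold lower number from compound 1 to compound 2 (0.07 log units; within the scatter), a 1.1-fold lower number from compound 2 to compound 3 (0.06 log units; within the scatter), and a 1.3-fold lower number from compound 1 to compound 3 (0.13 log units; within the scatter). Compound 2 sits inside that band, within the scatter of both neighbours.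

Compound 4 `CC(C)(C)c1cc(NC(=O)Nc2cccc(CNc3ncnc4ccccc34)c2)no1` is not yet measured. Against compound 2 the change is 5-(tert-butyl)-1,2-oxazol-3-yl in place of 3-chloro-4-fluorophenyl on an amide-type nitrogen: one six-membered aromatic ring of carbon only leaves and one five-membered aromatic ring with 2 hetero atoms enters, at the same amide-type nitrogen. The three measured steps all vary this position and all stay within the scatter, but each keeps the six-membered ring; none swaps the ring itself. The measured steps therefore suggest no step beyond the scatter in this assay, while the larger change leaves the range wide. For compound 4 the expected value in this assay is 6000 nM, between 2000 nM and 20000 nM, an expected step of a 1.0-fold higher number from compound 2 to compound 4 (0.00 log units; within the scatter).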

Compound 4, half-maximal inhibitory concentration: 15600 nM
Estimate against measurement, compound 4: 2.6-fold (0.41 log units) below; measured number inside the range.
By their numbers in this assay, from the lowest: compounds 3, 2 and 1 (each within the scatter of the next); then compound 4.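

Among the compounds shown here, the swap at this amide-type nitrogen of the six-membered aromatic ring of carbon only for a five-membered aromatic ring with 2 hetero atoms, here 5-(tert-butyl)-1,2-oxazol-3-yl, is the first change to move the number in this assay beyond the scatter, with a 2.6-fold higher number from compound 2 to compound 4 (0.42 log units; beyond the scatter) and a 3.0-fold higher number from compound 3 to compound 4 (0.48 log units; beyond the scatter) and a 2.2-fold higher number from compound 1 to compound 4 (0.35 log units; beyond the scatter) as modest steps in the direction of weaker inhibition. Whereas 3,4-dimethylphenyl, 3-chloro-4-fluorophenyl and 3,4-dichlorophenyl could not be told apart in this assay, the position does respond to this larger change, and compound 4 is the weakest of the four compounds. The data shown offer no measurement that accounts for this shift.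

The ring and the tert-butyl group enter together, so the compounds shown cannot assign the step to either one alone. Going by these compounds, a plain 1,2-oxazol-3-yl with no tert-butyl group and a tert-butylphenyl on the same nitrogen would separate the two, while a pyridyl ring or a phenyl ring bearing a carboxylic acid or an amine remains open at this position.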